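The compounds below may be only part of what the source reports. "The series", "measured", "known", "first", "only" and "open" are said of these compounds alone.

Compound 1 `Cc1cc(S(=O)(=O)Nc2nc3ccsc3c(=O)n2Cc2ccccc2)c(S)cc1Cl` and compound 2 `Cc1cc(S(=O)(=O)Nc2nc3cc(-c4ccccc4)sc3c(=O)n2Cc2ccccc2)c(S)cc1Cl` share one core and differ at a single aromatic carbon, where compound 2 carries phenyl in place of hydrogen. In a functional assay on M14 cells (Homo sapiens) for inhibition (a lower number here means a stronger inhibitor of growth, a higher number a weaker inhibitor of growth), compound 1 gives 19800 nM. Compound 2 reaches only the limit of this assay, > 100000 nM, so no number is known for it. Compound 2 thus stands at the limit of > 100000 nM in this assay, at which 1 of the 2 values shown sits, and the step of an at least 5.0-fold higher number from compound 1 to compound 2 (0.70 log units; beyond the scatter) is at least modest, in the direction of weaker growth inhibition. Compound 3 `Cc1cc(S(=O)(=O)Nc2nc3cc(-c4ccc(Cl)cc4)sc3c(=O)n2Cc2ccccc2)c(S)cc1Cl` is derived from compound 2 by chloro in place of hydrogen on an aromatic carbon. Going by the values given here, no measured pair shows what a chloro on that phenyl does in this assay. Among the compounds with values here, the only related step is an at least 5.0-fold higher number from compound 1 to compound 2 (0.70 log units; beyond the scatter), which carried compound 2 beyond the range of reported numbers. Compound 2 already sits at that limit. The step that the limit leaves unreadable from compound 2 to compound 3 is therefore expected to be small and not beyond the scatter. The estimate for compound 3 in this assay is 150000 nM, with a range from 50000 nM to 500000 nM, and compound 3 is expected most likely to be reported again only as a limit.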

Compound 3, concentration for 50% growth inhibition: > 100000 nM
Compound 3 was reported as a limit; the forecaster's own chance of this, stated with the estimate: 80%; the middle value does not contradict the limit.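

In this assay compound 3 gives > 100000 nM, which is a limit and not a number. Chloro on the phenyl therefore does not bring the compound back into the range of reported numbers, and the 4-chlorophenyl group, like phenyl, stands with weaker growth inhibition than the hydrogen of compound 1: the change gives an at least 5.0-fold higher number from compound 1 to compound 3 (0.70 log units; beyond the scatter). The step between compound 2 and compound 3 cannot be read, so it is unknown whether chloro strengthens, weakens or leaves unchanged the growth inhibition of the phenyl compound, and the values now gather at one end of the scale: the limit of > 100000 nM in this assay, at which 2 of the 3 values shown sit.

Going by these compounds, how far compound 2 and compound 3 lie past that limit remains open. Also open, on these data alone, is whether a small group such as methyl or an amine on the same aromatic carbon would stay near compound 1, and whether a carboxylic acid in place of the chloro on the phenyl would give a readable number.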